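The source may report more compounds than this note shows. Statements on the series, on what has been measured and on what is new or still open speak of the compounds shown alone.

Working notes on the thiazolo series, cytotoxicity read-out. Three members have numbers in a functional assay on MCF7 cells (Homo sapiens) for cytotoxicity, read by MTT assay, with a stated time of 96 h; on this read-out higher numbers stand for weaker inhibition and lower numbers for stronger inhibition. Compound 1 `Cc1c(CO)cc2n1[C@@H](c1ccccc1)SC2` gives 1900 nM in this assay. Compound 2 `Cc1c(COC(=O)NCc2ccccc2)cc2n1[C@@H](c1ccccc1)SC2`, carrying the benzylcarbamate on the hydroxymethyl oxygen, gives 1900 nM in this assay, a number that sits within the scatter of compound 1. Compound 3 `Cc1cc(CO)c2n1[C@@H](c1ccccc1)SC2` gives 19900 nM in this assay, the highest number of the three, and its gap to compound 1 as well as to compound 2 lies beyond the scatter, so compound 3 is the weakest inhibitor among the measured members.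

The next member is compound 4 `Cc1c(CO)c(CO)c2n1[C@@H](c1ccccc1)SC2`, which has not yet been measured in this assay. It differs from compound 3 by hydroxymethyl in place of hydrogen on an aromatic carbon. Compound 4 thus carries two hydroxymethyl groups on the shared core.

Among the compounds with values here, no measured pair spans this exact step, so its size is a guess. The step from compound 3 to compound 4 is expected to move toward a lower number, a 5.7-fold lower number from compound 3 to compound 4 (0.75 log units; beyond the scatter), since compound 1 gives 1900 nM and compound 2 gives 1900 nM in this assay. For compound 4 the estimate in this assay is 3500 nM, with a range from 900 nM to 14000 nM.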

Compound 4, half-maximal inhibitory concentration: 600 nM
For compound 4 the middle estimate is 5.8-fold (0.77 log units) above the measured one, and the stated range ends above it.
By their numbers in this assay, from the lowest: compound 4; then compounds 1 and 2 (each within the scatter of the next); then compound 3.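

On the aromatic carbon next to the ring atom that bears a methyl group, a hydroxymethyl in place of hydrogen gives a 33-fold lower number from compound 3 to compound 4 (1.52 log units; beyond the scatter) in this assay, the first sign that this position can change the number strongly in the series. Compound 4 also has the lowest number of the four, with the step of a 3.2-fold lower number from compound 1 to compound 4 (0.50 log units; beyond the scatter) being modest in size but beyond the scatter, so the second hydroxymethyl lowers the number whichever of the two singly substituted compounds it is added to. The data shown offer no measured explanation for either step.

The compounds shown leave open whether the hydroxymethyl is specifically required at this aromatic carbon, or whether an aminomethyl group, a carboxylic acid or a longer chain such as hydroxyethyl would give a similar step from compound 3. Also open, on these data alone, is whether a benzylcarbamate on either hydroxymethyl of compound 4 would leave its number unchanged, as the same group did between compound 1 and compound 2, whose values lie within the scatter of each other.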